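The source may report more compounds than this note shows. Statements on the series, on what has been measured and on what is new or still open speak of the compounds shown alone.

Compound 1 `Oc1cc(C(F)(F)F)ccc1-c1nc(-c2ccccc2O)n(-c2ccc(F)cc2)n1` gives 67.2% in a functional assay on PC-12 cells (Rattus norvegicus) for cytotoxicity, read by MTT assay, with stated times of 2 h and 24 h, tested at 1 uM; a lower number here means a weaker effect, a higher number a stronger effect of the compound at the concentration tested. Within the data shown here, compound 2 `Oc1cc(C(F)(F)F)ccc1-c1nc(-c2ccccc2O)n(-c2ccccc2Cl)n1` gives 70.1% in this assay, the top of the two numbers so far, but separated from compound 1 only by a number 2.9 percentage points higher from compound 1 to compound 2 (within the scatter), a gap within the scatter. Compound 3 `Oc1cc(C(F)(F)F)ccc1-c1nc(-c2ccccc2O)n(-c2cccc(C(F)(F)F)c2)n1` is not yet measured; its change against compound 2 is 3-(trifluoromethyl)phenyl in place of 2-chlorophenyl on an aromatic nitrogen. Among the measured compounds shown here, the one measured step on this aromatic nitrogen, a number 2.9 percentage points higher from compound 1 to compound 2 (within the scatter), is within the scatter, so no step beyond the scatter is expected here either. Compound 3 is therefore estimated at 68%, with a range of 55% to 80%. The expected step is a number 2.1 percentage points lower from compound 2 to compound 3 (within the scatter).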

Compound 3, a percentage reported as activity, at one concentration (the size of the read-out at that concentration, not a potency): 71.5%
Estimate against measurement, compound 3: 3.5 percentage points below; the range from low to high includes it.
By their numbers in this assay, from the lowest: compounds 1, 2 and 3 (each within the scatter of the next).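

With 3-(trifluoromethyl)phenyl on the aromatic nitrogen, this assay shows a number 1.4 percentage points higher from compound 2 to compound 3 (within the scatter) against 2-chlorophenyl and a number 4.3 percentage points higher from compound 1 to compound 3 (within the scatter) against 4-fluorophenyl in this series. This position therefore takes the 10-heavy-atom group, which also carries fluorine rather than chlorine, with neither step beyond the scatter, so the three substituted phenyl groups cannot be told apart here. The data offer no explanation for this flat result.

As far as these compounds go, it remains open whether a different kind of group on this nitrogen, such as an amine, a carboxylic acid or a longer alkyl chain, would give a step beyond the scatter.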